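The compounds below may be only part of what the source reports. "The series", "measured", "known", "first", "only" and "open" are said of these compounds alone.

Compound 1 `CCCNC(=O)Nc1cc2nc(C3CCCCC3)[nH]c2cc1N1CCCC1`: in an ADME assay on Vero cells (Chlorocebus sabaeus) for cytotoxicity, read by resazurin assay, with a stated time of 3 days (on this read-out higher numbers stand for weaker inhibition and lower numbers for stronger inhibition), compound 1 gives > 100 ug/mL, which is a limit of the assay rather than a number.
Compound 2 `COc1ccc(C(=O)Nc2cc3nc(C4CCCCC4)[nH]c3cc2N2CCCC2)cc1`: in this assay compound 2 gives > 100 ug/mL, again a limit.
Compound 3 `CCOCCOC(=O)Nc1cc2nc(C3CCCCC3)[nH]c2cc1N1CCCC1`: in this assay compound 3 gives > 100 ug/mL, also a limit.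

Compound 3 therefore stands where the other two stand, at the limit of > 100 ug/mL in this assay, at which 3 of the 3 values shown sit, with no number of its own. Compound 4 `O=C(NCc1ccccc1)Nc1cc2nc(C3CCCCC3)[nH]c2cc1N1CCCC1` differs from compound 3 in one place: benzylamino in place of 2-ethoxyethoxy on a carbonyl carbon. Among the measured compounds shown here, three measured steps bear on this change, each swapping the group on that same carbonyl carbon: a step that the two limits leave unreadable from compound 1 to compound 2, a step that the two limits leave unreadable from compound 1 to compound 3 and a step that the two limits leave unreadable from compound 2 to compound 3. None of them can be sized, since every value involved is the same limit. Within these compounds the shared core has shown no measurable cytotoxicity whatever group sits on the carbonyl carbon, and the benzylamino group is expected to fit that picture. The step of a number no higher from compound 3 to compound 4 (the limit leaves the size open) is accordingly expected to be none beyond the scatter. Compound 4 is expected to give about 100 ug/mL in this assay, within a range from 40 ug/mL to 250 ug/mL, most likely reported once more only as a limit.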

Compound 4, half-maximal inhibitory concentration: > 100 ug/mL
Compound 4 ended at the assay's limit; the forecaster's own chance of this, stated with the estimate: 80%; the middle value lies on the limit itself.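

Compound 4 gives a limit rather than a number, as do compound 1, compound 2 and compound 3, so no step among them can be read: the limit of > 100 ug/mL in this assay, at which 4 of the 4 values shown sit.

The compounds shown leave open whether the group on the carbonyl carbon changes the result in this assay at concentrations beyond that limit.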